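The source may report more compounds than this note shows. Statements on the series, on what has been measured and on what is new or still open speak of the compounds shown alone.

Measured so far in an assay on mitochondria from L6 cells (Rattus norvegicus) for activation, with a stated time of 90 min; on this read-out lower numbers stand for an effect already at smaller amounts and higher numbers for an effect only at larger amounts of compound:
compound 1 `CCCCOc1ccc(Nc2nc3nonc3nc2O)cc1` gives 3700 nM
compound 2 `Oc1nc2nonc2nc1Nc1ccc(OCc2ccccc2)cc1` gives 2400 nM
compound 3 `Oc1nc2nonc2nc1Nc1ccc(S(F)(F)(F)(F)F)cc1` gives 3900 nM

Compound 3 carries the highest of the three numbers, yet the steps of a 1.1-fold higher number from compound 1 to compound 3 (0.02 log units; within the scatter) and a 1.6-fold higher number from compound 2 to compound 3 (0.21 log units; within the scatter) both lie within the scatter, so the three numbers cannot be told apart. Compound 4 `Oc1nc2nonc2nc1Nc1ccc(SC(F)(F)F)cc1` differs from compound 3 in one place: a group of 5 heavy atoms (1 carbon, 3 fluorine, 1 sulfur; no ring) in place of a group of 6 heavy atoms (5 fluorine, 1 sulfur; no ring), on an aromatic carbon. Within the data shown here, the steps that bear on this are those that exchanged the group on the same aromatic carbon, a 1.1-fold higher number from compound 1 to compound 3 (0.02 log units; within the scatter) and a 1.6-fold higher number from compound 2 to compound 3 (0.21 log units; within the scatter); both stayed within the scatter, as did a 1.5-fold lower number from compound 1 to compound 2 (0.19 log units; within the scatter) further along the chain. Three different groups at that place gave numbers within the scatter of one another, so for compound 4 no step beyond the scatter is expected in this assay, a 1.1-fold lower number from compound 3 to compound 4 (0.05 log units; within the scatter). The estimate for compound 4 is 3500 nM, with a range of 1500 nM to 8000 nM.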

Compound 4, half-maximal effective concentration: 1400 nM
For compound 4 the middle estimate is 2.5-fold (0.40 log units) above the measured one, outside the stated range (below it).
By their numbers in this assay, from the lowest: compounds 4, 2, 1 and 3 (each within the scatter of the next, the first and the last beyond it).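

Among these compounds, on the aromatic carbon carrying the varied group, (trifluoromethyl)sulfanyl gives the first steps beyond the scatter in this assay (a 2.8-fold lower number from compound 3 to compound 4 (0.44 log units; beyond the scatter)) and (a 2.6-fold lower number from compound 1 to compound 4 (0.42 log units; beyond the scatter)), both modest. Against benzyloxy the same group stays within the scatter (a 1.7-fold lower number from compound 2 to compound 4 (0.23 log units; within the scatter)), so compound 4 and compound 2 cannot be told apart, and the place is less flat than the earlier compounds suggested. Nothing available here explains these steps. Still open, as far as these compounds go, is how a directly bound trifluoromethyl group, an amine or a carboxylic acid on that aromatic carbon would compare with (trifluoromethyl)sulfanyl. From the compounds shown here alone, whether these steps carry over to changes elsewhere on the shared core also stays open.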